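This account rests on a few compounds, and the source may have more. Where it says the series, first, only, none or still open, it means among the compounds named here.

In an ADME assay on RAW264.7 cells (Mus musculus) for cytotoxicity, read by resazurin assay, with a stated time of 48 h (on this read-out lower numbers stand for higher toxicity in this test and higher numbers for lower toxicity in this test), compound 1 `CCn1ncc2ccc(N/C(C)=C3\C(=O)C=C(C)OC3=O)cc21` gives > 100000 nM, which is a limit of the assay rather than a number. Compound 2 `C=CCn1ncc2ccc(N/C(C)=C3\C(=O)C=C(C)OC3=O)cc21` gives > 100000 nM, also a limit. The change between them is vinyl in place of methyl on a saturated chain carbon bound to an aromatic nitrogen, and the step it made is a step that the two limits leave unreadable from compound 1 to compound 2. Compound 3 `CCn1cc2ccc(N/C(C)=C3\C(=O)C=C(C)OC3=O)cc2n1` has the same atoms as compound 1 joined differently; the difference between the two cores is not broken down here. Compound 3 gives > 100000 nM, again a limit. Compound 4 `C=CCn1cc2ccc(N/C(C)=C3\C(=O)C=C(C)OC3=O)cc2n1` carries the same change, at the same place, as that from compound 1 to compound 2, namely (vinyl in place of methyl on a saturated chain carbon bound to an aromatic nitrogen). The step expected in this assay is a step that the limit leaves unreadable from compound 3 to compound 4, resting on compound 3 sitting at the limit of > 100000 nM in this assay, at which 3 of the 3 values shown sit, together with the other two. The expected value for compound 4 is 150000 nM, between 60000 nM and 400000 nM.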

Compound 4, half-maximal cytotoxic concentration: > 100000 nM
Compound 4 ended at the assay's limit; the forecaster's own chance of this, stated with the estimate: 85%; the middle value lies beyond the limit too.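

No step can be read from compound 3 to compound 4, because both values are limits of the assay, not numbers: the limit of > 100000 nM in this assay, at which 4 of the 4 values shown sit. The compounds shown leave open whether swapping methyl for vinyl alters toxicity in this assay at all.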